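The compounds below may be only part of what the source reports. "The series", "measured", "known", "first", "only" and "open" are said of these compounds alone.

Measured so far, in a functional assay with Oryctolagus cuniculus as the target; on this read-out higher numbers stand for weaker inhibition and lower numbers for stronger inhibition:

Compound 1, `COc1ccc(-c2nc(CN(C)C)sc2-c2ccc(OC)cc2)cc1`: 96 nM.
Compound 2, `COc1ccc(-c2nc(CNC(=O)NC(C)C)sc2-c2ccc(OC)cc2)cc1`: 42 nM.
Compound 3, `COc1ccc(-c2nc(CCC(=O)O)sc2-c2ccc(OC)cc2)cc1`: its value is a limit of the assay, < 100 nM.

Compound 1 gives the highest of the two numbers in this assay. Its nearest neighbour is compound 2, with a 2.3-fold lower number from compound 1 to compound 2 (0.36 log units; beyond the scatter). Compound 3 sits at a limit, (the limit of < 100 nM in this assay, at which 1 of the 3 values shown sits), so its distance from compound 1 cannot be read.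

Compound 4, `COc1ccc(-c2nc(C3=CCN(C)CC3)sc2-c2ccc(OC)cc2)cc1`, differs from compound 1 in one place: a group of 7 heavy atoms (6 carbon, 1 nitrogen; one six-membered non-aromatic ring with 1 hetero atom) in place of a group of 4 heavy atoms (3 carbon, 1 nitrogen; no ring), on an aromatic carbon. Both measured steps from compound 1 change the same position, the carbon bound to the shared core. The step to compound 2 was modest, and the step to compound 3 was left unreadable by the limit. Neither step introduced a ring, so they say little about the change to compound 4 beyond showing that this position tolerates different groups without a large loss. Compound 4 is therefore expected to show, in this assay, a step of a 1.2-fold lower number from compound 1 to compound 4 (0.08 log units; within the scatter), within the scatter. The estimate for compound 4 is 80 nM, expected to fall between 30 nM and 250 nM.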

Compound 4, half-maximal inhibitory concentration: < 10 nM
Compound 4 was reported as a limit; the forecaster's own chance of this, stated with the estimate: 10%; at least 8.0-fold (0.90 log units) between middle value and limit.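

Compound 4 stands at a limit of this assay, not at a number: the limit of < 10 nM in this assay, at which 1 of the 4 values shown sits.

Even so, setting the six-membered non-aromatic ring directly on the aromatic carbon gives an at least 9.6-fold lower number from compound 1 to compound 4 (0.98 log units; beyond the scatter), and the same position gives an at least 4.2-fold lower number from compound 2 to compound 4 (0.62 log units; beyond the scatter). The earlier readable change here, a 2.3-fold lower number from compound 1 to compound 2 (0.36 log units; beyond the scatter), showed only that a chain could be exchanged at this carbon, whereas these steps show that a ring-bearing group can lower the number much further, with its nitrogen kept and no net charge counted on either side.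

Going by these compounds, the steps involving compound 3 cannot be read, and how far compound 4 lies past its limit stays open. The compounds shown also do not separate the effect of the ring's double bond or of its nitrogen, which a saturated six-membered amine ring or an all-carbon ring would address.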